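This account rests on a few compounds, and the source may have more. Where it says the series, first, only, none or still open, it means among the compounds named here.

Of the compounds shown here, three have so far been measured in a functional assay on MOLT-4 cells (Homo sapiens) for inhibition, read by sulforhodamine B assay, with a stated time of 48 h; on this read-out lower numbers stand for higher toxicity in this test and higher numbers for lower toxicity in this test.

Compound 1 `O=C(Nc1cccc(-n2cc(-c3ccncc3)c(-c3ccc(Cl)c(O)c3)n2)c1)Nc1cccc(C(F)(F)F)c1` gives > 32500 nM, a limit of the test rather than a number.
Compound 2 `COc1cc(-c2nn(-c3cccc(NC(=O)Nc4cc(C(F)(F)F)cc(C(F)(F)F)c4)c3)cc2-c2ccncc2)ccc1Cl` gives > 50000 nM, also a limit.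
Compound 3 `COc1cc(-c2nn(-c3cccc(NC(=O)Nc4cccc(C(F)(F)F)c4)c3)cc2-c2ccncc2)ccc1Cl` gives > 50000 nM, again a limit.

Compound 2 thus stands at the upper edge of what this assay reports, as do two of the three values (the limit of > 50000 nM in this assay, at which 2 of the 3 values shown sit), the third sitting at a lower limit (the limit of > 32500 nM in this assay, at which 1 of the 3 values shown sits). Compound 4 `O=C(Nc1cccc(-n2cc(-c3ccncc3)c(-c3ccc(Cl)c(O)c3)n2)c1)Nc1cc(C(F)(F)F)cc(C(F)(F)F)c1` differs from compound 2 by hydrogen in place of methyl on an oxygen on an aromatic ring. Among the measured compounds shown here, two measured steps touch this region: a step that the two limits leave unreadable from compound 2 to compound 3 and a step that the two limits leave unreadable from compound 1 to compound 3, neither of which can be sized, since both ends are limits. No step beyond the scatter can therefore be foreseen in this assay . Compound 4 is expected to give about 50000 nM, roughly between 25000 nM and 100000 nM. The expected step is a number no higher from compound 2 to compound 4 (the limit leaves the size open), most likely ending at a limit again.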

Compound 4, concentration lethal to 50% of the cells: > 50000 nM
Compound 4: a limit, no number (the forecaster's own chance of this, stated with the estimate: 80%); the middle value lies on the limit itself.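

Compound 4, like compound 1 and compound 2, gives only a limit in this assay, and neither step to compound 4 can be read. From the compounds shown here alone, whether hydroxy or methoxy, or the added trifluoromethyl, changes toxicity in this test remains open.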